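Adding propyl to the formyl compound: working notes

The compounds below may be only part of what the source reports. "The series", "measured", "known", "first", "only" and "open" are said of these compounds alone.

Measured compounds, all in a functional assay on the whole organism with Mus musculus as the target; on this read-out lower numbers stand for an effect already at smaller amounts and higher numbers for an effect only at larger amounts of compound:
- compound 1 `CCCN(c1ccncc1)n1cccc1`: > 20 mg/kg
- compound 2 `Clc1cccn1Nc1ccncc1`: > 20 mg/kg
- compound 3 `O=Cc1cccn1Nc1ccncc1`: > 20 mg/kg

Compound 3 stands at > 20 mg/kg, which is a limit and not a number. The other two compounds give limits as well, so the whole series sits at the limit of > 20 mg/kg in this assay, at which 3 of the 3 values shown sit. For the measured compounds named here, no measured compound yet gives a number to work from.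

Compound 4 `CCCN(c1ccncc1)n1cccc1C=O` follows from compound 3 by one change, (propyl in place of hydrogen on a nitrogen on an aromatic ring), that is, propyl in place of hydrogen on a nitrogen on an aromatic ring. Going by the values given here, no measured step covers this change directly. Among the compounds with values here, the one measured step is a step that the two limits leave unreadable from compound 2 to compound 3, and it offers no size to carry over. Compound 1 already carries propyl but has no formyl, and it gives > 20 mg/kg, again a limit. That value offers no sign that propyl brings a measurable effect, though it cannot rule one out.

No firm direction is expected in this assay, and the most likely outcome is another limit. The estimated step is a step that the limit leaves unreadable from compound 3 to compound 4. For compound 4 the expected value is 25 mg/kg, with an estimated range of 8 mg/kg to 80 mg/kg.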

Compound 4, dose for half-maximal effect: > 20 mg/kg
Compound 4 was reported as a limit; the forecaster's own chance of this, stated with the estimate: 70%; the middle value is on the limit's open side.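

In this assay compound 4 gives > 20 mg/kg, which is a limit and not a number. No size can therefore be read for the steps to compound 4 from compound 3 or compound 1, and the series stays at one limit: the limit of > 20 mg/kg in this assay, at which 4 of the 4 values shown sit.

The compounds shown leave open whether any of them would give a numerical value in this assay.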